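From chloro to butyl on the shared core

A few compounds are considered here, and "the series" means these few. Any claim that something is new, unique, unknown or untested is made for them only; others in the source may bear on it.

Two compounds measured so far in a functional assay on the whole organism (stomach) with Rattus norvegicus as the target (a lower number here means that less compound is needed, a higher number that more compound is needed for the effect), give these doses
Compound 1 `CCCc1ccc(C(=O)Nc2cc(C(=O)O)cc(C(=O)O)c2)cc1` with 94.2 mg/kg as its dose
Compound 2 `O=C(O)c1cc(NC(=O)c2ccc(Cl)cc2)cc(C(=O)O)c1` with 97.3 mg/kg as its dose

Compound 2 stands level with compound 1, since the two values lie within the scatter of each other. Among the compounds with values here, compound 3 `CCCCc1ccc(C(=O)Nc2cc(C(=O)O)cc(C(=O)O)c2)cc1` has not yet been measured, and no measured compound carries butyl. The structural change from compound 2 is butyl in place of chloro on an aromatic carbon and it amounts to butyl in place of chloro on an aromatic carbon.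

Within the data shown here, the one measured step that bears on this is a 1.0-fold higher number from compound 1 to compound 2 (0.01 log units; within the scatter) and, read the other way, it puts propyl, a chain like butyl, in place of chloro. With that single step as the guide, no change beyond the scatter is expected in this assay when butyl enters. The expected step is a 1.1-fold lower number from compound 2 to compound 3 (0.03 log units; within the scatter) and it would leave the number where it stands. For compound 3 the estimate is 90 mg/kg as the expected dose, with 42 mg/kg and 190 mg/kg as the ends of the expected range.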

Compound 3, dose for 50% inhibition: 91.9 mg/kg
Compound 3: middle estimate off by 1.0-fold (0.01 log units), on the low side; the range from low to high includes it.
By their numbers in this assay, from the lowest: compounds 3, 1 and 2 (each within the scatter of the next).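

In this assay, replacing chloro with butyl, a single chlorine atom with a chain of 4 carbon atoms, gives a 1.1-fold lower number from compound 2 to compound 3 (0.02 log units; within the scatter), so at this position, para to a large group, the larger group keeps the dose within the scatter of the smaller one. Within the data shown here, the extension of the propyl chain, with methyl in place of hydrogen on a saturated chain carbon, gives a 1.0-fold lower number from compound 1 to compound 3 (0.01 log units; within the scatter) and provides the first direct comparison of two chains here, which also stays within the scatter. Chloro, propyl and butyl therefore stand level at this position in the three compounds, and nothing measured here accounts for that.

Going by these compounds, it remains open whether an amine, a hydroxyl group or a chain longer than butyl at this position would move the dose beyond the scatter, or whether the level values would continue with such groups. The rest of the shared core is identical in all three compounds, so they give no information on what a change elsewhere on it would do to the dose.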